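The source may report more compounds than this note shows. Statements on the series, on what has been measured and on what is new or still open speak of the compounds shown alone.

Measured compounds, with their values in an ADME assay on HEK293 cells (Homo sapiens) for inhibition, read by MTT assay, with stated times of 18 h and 4 h (a lower number here means a stronger inhibitor, a higher number a weaker inhibitor), given after each:
- compound 1 (`CCCCCCCCCCCCCCCCOP(=O)(O)OCCSC(=S)N1CCN(C)CC1`) gives > 100000 nM as a limit
- compound 2 (`CCCCCCOP(=O)(O)OCCSC(=S)N1CCCC1`) gives > 100000 nM as a limit

Compound 2 has no number of its own in this assay and stands only at a limit (> 100000 nM). Compound 1 stands in the same place, so the measurements so far amount to a single reading (the limit of > 100000 nM in this assay, at which 2 of the 2 values shown sit).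

Compound 3 (`CCCCCCOP(=O)(O)OCCSC(=S)N1CCN(C)CC1`) differs from compound 2 in one place, with 4-methylpiperazin-1-yl in place of pyrrolidin-1-yl on a thiocarbonyl carbon. Within the data shown here, no measured pair of compounds shows what a change of this kind does in this assay, so the size of the step has to be estimated without a direct guide. Since compound 2 sits at a limit (> 100000 nM), no step beyond the scatter is expected, and compound 3 will most likely be reported as a limit too. The estimated step is a number no higher from compound 2 to compound 3 (the limit leaves the size open) and no larger. For compound 3 the expected value is 100000 nM with an estimated range from 40000 nM to 200000 nM as its upper end.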

Compound 3, half-maximal inhibitory concentration: > 100000 nM
Compound 3 ended at the assay's limit (the forecaster's own chance of this, stated with the estimate: 80%); the middle value sits exactly at the limit.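

In this assay compound 3 gives > 100000 nM, which is a limit. The steps to compound 3 from compound 1 and from compound 2 cannot be read, because all three compounds share one reading: the limit of > 100000 nM in this assay, at which 3 of the 3 values shown sit.

The compounds shown leave open what either change, 4-methylpiperazin-1-yl in place of pyrrolidin-1-yl or hydrogen in place of decyl, does to inhibition.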